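Cyclohexyl for sec-butyl on an enaminone amine

A few compounds are considered here, and "the series" means these few. Any claim that something is new, unique, unknown or untested is made for them only; others in the source may bear on it.

In a functional assay on HT-29 cells (Homo sapiens) for inhibition, read by MTT assay, with a stated time of 72 h (on this read-out lower numbers stand for stronger inhibition and higher numbers for weaker inhibition), compound 1, with the structure `CCC(C)NC(=C\C(=O)/C=C/c1ccc(O)c(OC)c1)/C=C/c1ccc(O)c(OC)c1`, reaches only the limit of the assay, > 25000 nM. Compound 2, with the structure `COc1cc(/C=C/C(=O)/C=C(/C=C/c2ccc(O)c(OC)c2)NC2CCCCC2)ccc1O`, likewise reaches only the limit of this assay, > 25000 nM. Between them stands one change, (cyclohexyl in place of sec-butyl on an amine nitrogen), and the step that the two limits leave unreadable from compound 1 to compound 2 cannot be read, since both values sit at the limit of > 25000 nM in this assay, at which 2 of the 3 values shown sit. Compound 3, with the structure `CCC(C)NC(=C\C(=O)/C=C/c1ccc(O)cc1)/C=C/c1ccc(O)cc1`, is the only one of the three that gives a number in this assay, 13000 nM. How the core of compound 3 differs from the core of compound 1 is not broken down here.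

Compound 4, with the structure `O=C(/C=C(/C=C/c1ccc(O)cc1)NC1CCCCC1)/C=C/c1ccc(O)cc1`, has not been measured in this assay. It differs from compound 3 by cyclohexyl in place of sec-butyl on an amine nitrogen, the same change as that from compound 1 to compound 2, made at the same place on the amine nitrogen. Going by the values given here, that earlier step gives no readable size, so no measured step can guide the expectation, and it rests on compound 3 alone with its value 13000 nM. The expected step is a 1.2-fold higher number from compound 3 to compound 4 (0.09 log units; within the scatter), estimated as small. Compound 4 is therefore expected to give about 16000 nM in this assay, most likely between 6000 nM and 40000 nM.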

Compound 4, half-maximal inhibitory concentration: 4000 nM
Beside the measured number, compound 4's estimate is 4.0-fold (0.60 log units) above it; the whole stated range lies above it.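

In this assay, cyclohexyl in place of sec-butyl on the amine nitrogen gives a 3.3-fold lower number from compound 3 to compound 4 (0.51 log units; beyond the scatter), so in this one pair the change goes with stronger inhibition. The same change on the core of compound 1, which leads to compound 2, cannot be read, because neither value is a number, only a limit of the assay: the limit of > 25000 nM in this assay, at which 2 of the 4 values shown sit. This gives one readable step on one core, and it does not show that the change carries over from one core to another, since whatever the swap does on the core of compound 1 stays hidden behind those limits.

The compounds shown carry only sec-butyl and cyclohexyl on this nitrogen, so it remains open whether a small group such as methyl, an open chain such as hexyl or an aromatic ring such as phenyl would match compound 4 at 4000 nM or move away from it. On these data alone, it also remains open how cyclohexyl would behave on a core where a fluorine or an amine stands in place of the methoxy group, which would give a second readable test of the change.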